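Aryl replacement on the shared core: compound 4

The source may report more compounds than this note shows. Statements on the series, on what has been measured and on what is new or still open speak of the compounds shown alone.

Measured in a functional assay on HeLa cells (Homo sapiens) for inhibition, read by CCK-8 assay, with a stated time of 48 h; a higher number here means a weaker inhibitor, a lower number a stronger inhibitor:
compound 1 `COc1cc(-c2ccnc3cc(-c4ccc(F)cc4)nn23)cc(OC)c1OC` gives 5840 nM
compound 2 `COc1cc(-c2ccnc3cc(-c4ccc5cc[nH]c5c4)nn23)cc(OC)c1OC` gives 125 nM
compound 3 `COc1cc(-c2ccnc3cc(-c4cccc(C)c4)nn23)cc(OC)c1OC` gives 4230 nM

Compound 1 carries the highest of the three numbers in this assay. Compound 3 sits within the scatter of it, a 1.4-fold lower number from compound 1 to compound 3 (0.14 log units; within the scatter), while compound 2 lies far away, a 47-fold lower number from compound 1 to compound 2 (1.67 log units; beyond the scatter). Compound 4 `COc1ccc(-c2cc3nccc(-c4cc(OC)c(OC)c(OC)c4)n3n2)cc1N` differs from compound 1 by 3-amino-4-methoxyphenyl in place of 4-fluorophenyl on an aromatic carbon. Both measured steps start from compound 1 and bear on this change: replacing 4-fluorophenyl by 3-methylphenyl moved nothing beyond the scatter, whereas replacing it by 1H-indol-6-yl gave a large drop. The 3-amino-4-methoxyphenyl entering here is, like the indolyl, a group with a hydrogen-bond donor, so a drop beyond the scatter is expected, with the size set by a 47-fold lower number from compound 1 to compound 2 (1.67 log units; beyond the scatter) as an upper bound. Compound 4 is estimated at 400 nM, range 80 nM to 2000 nM, an expected step of a 15-fold lower number from compound 1 to compound 4 (1.16 log units; beyond the scatter).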

Compound 4, half-maximal inhibitory concentration: 283 nM
Compound 4: the middle estimate sits 1.4-fold (0.15 log units) above what was measured; low and high end bracket the measured number.
By their numbers in this assay, from the lowest: compound 2; then compound 4; then compounds 3 and 1 (each within the scatter of the next).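

At this aromatic carbon of the shared core, a single-ring aryl group bearing a hydrogen-bond donor also gives a large step in this assay, a 21-fold lower number from compound 1 to compound 4 (1.31 log units; beyond the scatter), and against the methyl-bearing ring, a 15-fold lower number from compound 3 to compound 4 (1.17 log units; beyond the scatter). A large gain is therefore not confined to the fused 1H-indol-6-yl, although a 2.3-fold higher number from compound 2 to compound 4 (0.35 log units; beyond the scatter) leaves compound 2 with a modest edge. No evidence at hand accounts for these steps.

From the compounds shown here alone, whether the amine or the methoxy group of 3-amino-4-methoxyphenyl drives the step remains open. So does the outcome with a 3-hydroxyphenyl or 3-aminophenyl group here.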